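The source may report more compounds than this note shows. Statements on the series, on what has been measured and on what is new or still open speak of the compounds shown alone.

Of the compounds shown here, three have so far been tested in a functional assay on the whole organism (plasma, strain Sprague-Dawley) with Rattus norvegicus as the target, with a stated time of 2 h, at a dose of 12.5 mg/kg by the oral route; a lower number here means a weaker effect, a higher number a stronger effect of the compound at the dose given. Compound 1 `c1ccc(C(/N=C2\CCCCCN2)C2CC2)cc1` gives 5%. Compound 2 `c1ccc(C(/N=C2\CCCCCCN2)C2CC2)cc1` gives 0%; the difference between the cores of compound 1 and compound 2 is not broken down here. Compound 3 `c1ccc(C(/N=C2\CCCCCN2)c2ccco2)cc1` gives 5%. Compound 3 differs from compound 1 by furan-2-yl in place of cyclopropyl on a saturated chain carbon bound to an aromatic carbon and a double-bonded nitrogen, and the step of no change at the digits printed from compound 1 to compound 3 (within the scatter). Compound 4 `c1ccc(C(/N=C2\CCCCCCN2)c2ccco2)cc1` has not yet been measured. It differs from compound 2 by furan-2-yl in place of cyclopropyl on a saturated chain carbon bound to an aromatic carbon and a double-bonded nitrogen, the same change made on the core of compound 2 instead. Because the step of no change at the digits printed from compound 1 to compound 3 (within the scatter) stayed within the scatter, the expected step of a number 2 percentage points higher from compound 2 to compound 4 (within the scatter) is similarly flat. Compound 4 is therefore estimated at 2%, with a likely range from 0% to 12%.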

Compound 4, a percentage reported as inhibition, in the whole organism at one dose (the size of the read-out at that dose, not a potency): 22%
The estimate for compound 4 lay 20 percentage points below the measured number; the whole stated range lies below it.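

In this assay, putting furan-2-yl in place of cyclopropyl gives a number 22 percentage points higher from compound 2 to compound 4 (beyond the scatter). Within the data shown here, the effect of this change therefore does not carry over unchanged from one core to the other: the same change on two cores in this assay, no change at the digits printed (within the scatter) from compound 1 to compound 3 and a number 22 percentage points higher (beyond the scatter) from compound 2 to compound 4, 22 percentage points apart, beyond the scatter of two such steps This shows that the result of the swap depends on the core it is made on, but with only one pair per core, read at a single dose and time, it does not show why the two cores differ or how general the difference is.

Going by these compounds, how a thiophen-2-yl ring or a longer alkyl chain would behave at the same place remains open. So does whether furan-2-yl would give a similar rise on any further core.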